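The source may hold more compounds than are shown below. What is called first, only, known or untested is meant among the compounds shown, and "the series" means these compounds.

Among the compounds with values here, the series so far holds two measured compounds. In an assay on isolated protein for inhibition of inositol monophosphatase 1 (Bos taurus) (on this read-out lower numbers stand for stronger inhibition and higher numbers for weaker inhibition), compound 1 `O=P(O)(O)O[C@H]1CO[C@H](CO)[C@H]1O` gives 2900000 nM, and compound 2 `O=P(O)(O)O[C@@H]1CO[C@@H](CO)[C@@H]1O` gives 1800000 nM; the step of a 1.6-fold lower number from compound 1 to compound 2 (0.21 log units; within the scatter) leaves the two numbers within the scatter of each other, and the fact that compounds 1 and 2 differ only in the configuration as drawn is all that separates the two structures. Compound 1 thus stands at one of two numbers that cannot be told apart.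

Compound 3 `O=P(O)(O)O[C@H]1COC[C@H]1O` is the next structure to go into this assay. Relative to compound 1 the change is hydrogen in place of hydroxymethyl on a saturated ring carbon. Within the data shown here, no measured step touches this group: the only step in hand, from compound 1 to compound 2, concerns configuration alone and stayed within the scatter, so it gives no direction for the removal of the hydroxymethyl. Any expectation for this assay therefore rests on no measured precedent, and only a modest step of a 1.6-fold higher number from compound 1 to compound 3 (0.19 log units; within the scatter) towards a higher number is expected, with a wide range around it. Compound 3 is estimated at 4500000 nM, between 1500000 nM and 14000000 nM.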

Compound 3, half-maximal inhibitory concentration: 3600000 nM
Beside the measured number, compound 3's estimate is 1.3-fold (0.10 log units) above it; low and high end bracket the measured number.
By their numbers in this assay, from the lowest: compounds 2, 1 and 3 (each within the scatter of the next).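

With hydrogen in place of hydroxymethyl on a saturated ring carbon, next to the ring oxygen, the result is a 1.2-fold higher number from compound 1 to compound 3 (0.09 log units; within the scatter), so compound 3 cannot be told apart from compound 1 in this assay. Within the data shown here, compounds 1 and 2 spoke only to configuration as drawn; this is the first reading on a substituent, and in this assay the hydroxymethyl at this position makes no difference that can be resolved, so the group can be dropped without a measurable step from compound 1. Nothing at hand bears on why this change leaves the number within the scatter.

On these data alone, it remains open whether any other group on this ring carbon, such as a carboxylic acid, an amine or a longer chain, would move the number beyond the scatter, given that only hydroxymethyl and hydrogen are compared here. Also open, as far as these compounds go, is whether a change at the ring atom that bears a hydroxy group, or at the ring atom that bears the group of 5 heavy atoms, would give a step that can be read.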